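The source may hold more compounds than are shown below. What is called first, only, known or untested is meant among the compounds shown, and "the series" means these compounds.

Measured in an ADME assay on BCBL1 cells (Homo sapiens) for cytotoxicity, with a stated time of 7 days (a lower number here means that less compound is tolerated, a higher number that more compound is tolerated), each value being a limit of the assay and not a number:
compound 1 `C=CCOc1nc(N)nc2c1ncn2/C=C1/CC1(CO)CO`: > 20000 nM
compound 2 `Nc1nc(OCc2ccccc2)c2ncn(/C=C3/CC3(CO)CO)c2n1`: > 20000 nM
compound 3 `CCCSc1nc(N)nc2c1ncn2/C=C1/CC1(CO)CO`: > 20000 nM

Compound 1 is known only through its limit, > 20000 nM. The series as a whole shows (the limit of > 20000 nM in this assay, at which 3 of the 3 values shown sit). Compound 4 `Nc1nc(NCc2ccccc2)c2ncn(/C=C3/CC3(CO)CO)c2n1` differs from compound 1 as follows: benzylamino in place of allyloxy on an aromatic carbon. The measured steps that bear on this change are a step that the two limits leave unreadable from compound 1 to compound 2, a step that the two limits leave unreadable from compound 1 to compound 3 and a step that the two limits leave unreadable from compound 2 to compound 3. None has a readable size, so none can be carried over. No step beyond the scatter is expected in this assay, and no direction can be assigned. The expected step is a number no higher from compound 1 to compound 4 (the limit leaves the size open). Compound 4 is estimated at 20000 nM, with an expected range of 8000 nM to 40000 nM.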

Compound 4, half-maximal cytotoxic concentration: 19900 nM
Compound 4: middle estimate off by 1.0-fold (0.00 log units), on the high side, within the range that was stated.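

In this assay, among the compounds shown here, compound 4, with benzylamino on the aromatic carbon next to the ring nitrogen, gives 19900 nM, the only value at this position that is a number, and benzylamino in place of allyloxy gives a number no higher from compound 1 to compound 4 (the limit leaves the size open). Compound 2, with benzyloxy at the same carbon, is known only through a limit, > 20000 nM. Benzylamino in place of propylsulfanyl gives a number no higher from compound 3 to compound 4 (the limit leaves the size open), and benzylamino in place of benzyloxy gives a number no higher from compound 2 to compound 4 (the limit leaves the size open). None of these three steps can therefore be read, and no size can be given for this change: the limit of > 20000 nM in this assay, at which 3 of the 4 values shown sit.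

Still open, going by these compounds, is what a smaller amine such as methylamino or a cyclic amine such as piperidine would give at this carbon.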